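This account rests on a few compounds, and the source may have more. Where it says the series, first, only, none or still open, it means among the compounds named here.

Compound 1 `Cc1nc(Nc2ccc(Cl)cc2)c2cc[nH]c2n1` in a functional assay on the whole organism for inhibition, with Nicotiana tabacum as the target (on this read-out higher numbers stand for weaker inhibition and lower numbers for stronger inhibition), gives 224000000 nM.
Compound 2 `CCOc1ccc(Nc2[nH]c(C)nc3nccc2-3)cc1` in this assay gives 347000000 nM.
Compound 3 `Cc1nc2nccc-2c(Nc2ccc(C(C)C)cc2)[nH]1` in this assay gives 45700000 nM.

Among these three numbers compound 1 stands second highest. Its number and that of compound 2 lie within the usual scatter of each other, so nothing separates them; compound 3 has a number well below that of compound 1, beyond the scatter.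

Compound 4 `Cc1nc(Nc2ccc(C#N)cc2)c2cc[nH]c2n1` differs from compound 1 in one place: cyano in place of chloro on an aromatic carbon, on an aromatic carbon of a six-membered aromatic ring of carbon only, para to a large group. Only one single-place step has been measured among these compounds, a 7.6-fold lower number from compound 2 to compound 3 (0.88 log units; beyond the scatter). That step concerns an exchange of ethoxy for isopropyl, not of chloro for cyano, so it does not speak directly to the change at hand. For the measured compounds named here, with no step that bears on it, the expectation is for a change no larger than the scatter, a 1.1-fold higher number from compound 1 to compound 4 (0.05 log units; within the scatter). Compound 4 is therefore estimated at 250000000 nM, within a range from 80000000 nM to 800000000 nM.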

Compound 4, half-maximal inhibitory concentration: 501000000 nM
Compound 4: the middle estimate sits 2.0-fold (0.30 log units) below what was measured; the range from low to high includes it.
By their numbers in this assay, from the lowest: compound 3; then compounds 1, 2 and 4 (each within the scatter of the next, the first and the last beyond it).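

At this carbon of the six-membered aromatic ring of carbon only, para to a large group, the choice of group does register in this assay: cyano in place of chloro gives a 2.2-fold higher number from compound 1 to compound 4 (0.35 log units; beyond the scatter), a modest move towards weaker inhibition. The exchange puts two heavy atoms where there was one and adds a triple bond and a hydrogen-bond acceptor, and this single step shows that such a swap is not neutral here. Nothing measured here accounts for the shift, so the step stands as an observation without an explanation.

On these data alone, whether an amine, a carboxylic acid or a longer chain at this carbon would move the number up or down remains open. So does whether cyano in place of chloro would give a similar step on any other compound.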